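Swapping amino for nitro at the assay limit

The compounds below may be only part of what the source reports. "The series", "measured", "known", "first", "only" and "open" are said of these compounds alone.

Of the compounds shown here, two sharing a core have been tested in a functional assay on HeLa cells (Homo sapiens) for antiproliferative activity, read by MTT assay, with a stated time of 72 h; a lower number here means a stronger inhibitor, a higher number a weaker inhibitor. Compound 1 (`COc1cc(-c2ncnn2-c2ccc(Cl)cc2Cl)cc(OC)c1OC`) gives > 10000 nM, which is a limit of the assay and not a number. Compound 2 (`COc1cc(-c2ncnn2-c2cccc(N)c2)cc(OC)c1OC`) gives > 10000 nM, again only a limit. Compound 2 therefore has no exact position on the scale.

Compound 3 (`COc1cc(-c2ncnn2-c2cccc([N+](=O)[O-])c2)cc(OC)c1OC`) keeps the core of compound 2 and carries nitro in place of amino on an aromatic carbon. Among the measured compounds shown here, the one measured step that could bear on this is a step that the two limits leave unreadable from compound 1 to compound 2. It exchanges a different group and its size cannot be read, so it offers no size or direction to carry over.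

A clear jump for compound 3 in this assay is not expected, because the limit of > 10000 nM in this assay, at which 2 of the 2 values shown sit, leaves no measured gain to extend. The assay may well report a limit again. The expected change is small and has no firm direction: a step that the limit leaves unreadable from compound 2 to compound 3. The estimated value for compound 3 is 12000 nM, with an expected range from 3000 nM to 40000 nM.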

Compound 3, half-maximal inhibitory concentration: > 10000 nM
Compound 3: no number, only a limit; the forecaster's own chance of this, stated with the estimate: 70%; the middle value does not contradict the limit.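

In this assay compound 3 gives > 10000 nM, which is a limit of the assay and not a number. The step between compound 2 and compound 3 therefore cannot be read, for this reason: the limit of > 10000 nM in this assay, at which 3 of the 3 values shown sit.

The compounds shown leave open how amino and nitro compare on this core, and whether any compound sharing it gives an exact value.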